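A Chlorine-Bearing Analogue Awaits Measurement

The source may hold more compounds than are shown below. What is called first, only, known or untested is meant among the compounds shown, and "the series" means these compounds.

Of the compounds shown here, three built on one shared core have been tested in an assay on isolated protein for inhibition of Amine oxidase [flavin-containing] A (Homo sapiens), read by fluorescence, with a stated time of 15 min; on this read-out higher numbers stand for weaker inhibition and lower numbers for stronger inhibition. Compound 1 `CCOc1ccc2cc(C(=O)/C=C/c3c(/C=C/c4ccc(OC)cc4)cc(OC)cc3OC)c(=O)oc2c1` gives 7070 nM. Compound 3 `CCOc1cccc2cc(C(=O)/C=C/c3c(/C=C/c4ccc(OC)cc4)cc(OC)cc3OC)c(=O)oc12` gives 3200 nM. For compound 2 `COc1ccc(/C=C/c2cc(OC)cc(OC)c2/C=C/C(=O)c2cc3cccc(C)c3oc2=O)cc1` the assay returned only a limit, > 60000 nM, which is the limit of > 60000 nM in this assay, at which 1 of the 3 values shown sits. Compound 2 therefore stands at the weak end of what has been measured, without a finished number of its own. Going by the values given here, the only measured step that touches compound 2 is an at least 18-fold lower number from compound 2 to compound 3 (1.27 log units; beyond the scatter), so exchanging the methyl for an ethoxy moved the inhibition strongly. Compound 4 `COc1ccc(/C=C/c2cc(OC)cc(OC)c2/C=C/C(=O)c2cc3cc(Cl)ccc3oc2=O)cc1` is not yet measured; it differs from compound 2 by a group of 12 heavy atoms (9 carbon, 2 oxygen, 1 chlorine; one six-membered aromatic ring of carbon only, one six-membered aromatic ring with 1 hetero atom) in place of a group of 12 heavy atoms (10 carbon, 2 oxygen; one six-membered aromatic ring of carbon only, one six-membered aromatic ring with 1 hetero atom), on a carbonyl carbon, meaning the methyl on the aromatic carbon is gone and a chlorine sits on the core instead. Among the compounds with values here, no measured step shows a chlorine at this place, so the only guide is that compound 2 sat at the limit while the two ethoxy compounds gave finished numbers. The estimate for compound 4 is 15000 nM, with a range from 4000 nM to 60000 nM. The expected step is therefore an at least 4.0-fold lower number from compound 2 to compound 4 (0.60 log units; beyond the scatter).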

Compound 4, half-maximal inhibitory concentration: > 60000 nM
Compound 4 was reported as a limit (the forecaster's own chance of this, stated with the estimate: 30%); at least 4.0-fold (0.60 log units) between middle value and limit.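

Compound 4, like compound 2, returned only a limit and not a finished number, so the step between these two compounds cannot be read: the limit of > 60000 nM in this assay, at which 2 of the 4 values shown sit.

The compounds shown leave open whether compound 4, with its chlorine, or compound 2, with its methyl, inhibits more strongly.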